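The source may report more compounds than this note shows. Statements on the series, on what has been measured and on what is new or still open speak of the compounds shown alone.

In an assay on cells (Ventricular myocyte) for inhibition of potassium voltage-gated channel subfamily KQT member 1 (Cavia porcellus), read by patch clamp (on this read-out lower numbers stand for stronger inhibition and higher numbers for weaker inhibition), compound 1 `CN1CCN(CCCCN2C(=O)CN(/N=C3\CCOc4ccc(C(N)=O)cc43)C2=O)CC1` gives 330 nM. In this assay compound 2 `COc1ccc2c(c1)/C(=N/N1CC(=O)N(CCCCN3CCCCC3)C1=O)CCO2` gives 22000 nM, the higher of the two numbers, with compound 1 standing at a far lower number, a gap that lies well beyond the scatter. Compound 3 `Cc1ccc2c(c1)/C(=N/N1CC(=O)N(CCCCN3CCCCC3)C1=O)CCO2` differs from compound 2 by methyl in place of methoxy on an aromatic carbon. Among the measured compounds shown here, no measured pair shows this same change, so the step is expected to be small, at most a slight drift toward a lower number, with a 1.5-fold lower number from compound 2 to compound 3 (0.17 log units; within the scatter) anticipated. The estimate for compound 3 in this assay is 15000 nM, ranging from 5000 nM to 45000 nM.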

Compound 3, half-maximal inhibitory concentration: 18900 nM
The estimate for compound 3 lay 1.3-fold (0.10 log units) below the measured number; measured number inside the range.
By their numbers in this assay, from the lowest: compound 1; then compounds 3 and 2 (each within the scatter of the next).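

In this assay, methyl in place of methoxy on this aromatic carbon gives a 1.2-fold lower number from compound 2 to compound 3 (0.07 log units; within the scatter) and so leaves the two numbers within the scatter of each other. This single change therefore shows that, with this side chain, removing the oxygen and its hydrogen-bond acceptor does not separate the compounds, which the earlier pair could not show, as compound 1 differs from compound 2 in more than one place. No evidence at hand explains this result. From the compounds shown here alone, whether an amine or a carboxylic acid on this aromatic carbon would shift the number stays open. Also open is which of the places where compound 1 differs from compound 2 accounts for the gap between them.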